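Compound 3 after the cyano to nitro change

A few compounds are considered here, and "the series" means these few. Any claim that something is new, unique, unknown or untested is made for them only; others in the source may bear on it.

compound 1 `COc1ccc(Nc2cc(Oc3c(C)cc(Br)cc3C)c([N+](=O)[O-])cc2[N+](=O)[O-])cc1`: 51200 nM
compound 2 `Cc1cc(Br)cc(C)c1Oc1cc(Nc2ccc(C#N)cc2)c([N+](=O)[O-])cc1[N+](=O)[O-]`: > 51700 nM

Both values come from an ADME assay on H9 cells (Homo sapiens) for cytotoxicity, read by XTT assay, with a stated time of 6 days; a lower number here means that less compound is tolerated, a higher number that more compound is tolerated. Compound 2 stands at the limit of > 51700 nM in this assay, at which 1 of the 2 values shown sits, so its value is a limit of the assay and not a number.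

Compound 3 `Cc1cc(Br)cc(C)c1Oc1cc(Nc2ccc([N+](=O)[O-])cc2)c([N+](=O)[O-])cc1[N+](=O)[O-]` differs from compound 2 by nitro in place of cyano on an aromatic carbon, para to a large group: nitro in place of cyano on an aromatic carbon.

For the measured compounds named here, one measured step bears on this change, cyano in place of methoxy on an aromatic carbon: a number no lower from compound 1 to compound 2 (the limit leaves the size open). Going by the values given here, its size stays open, and no measured step involves nitro. The evidence therefore supports no expected shift beyond the scatter, in either direction, though the uncertainty is wide.

The expected change is an at least 1.1-fold lower number from compound 2 to compound 3 (0.06 log units; that floor lies within the scatter).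

For compound 3 the estimated value in this assay is 45000 nM, with an expected range of 15000 nM to 70000 nM.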

Compound 3, half-maximal cytotoxic concentration: > 49700 nM
Compound 3 ended at the assay's limit (the forecaster's own chance of this, stated with the estimate: 55%); at least 1.1-fold (0.04 log units) between middle value and limit.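

For compound 3, > 49700 nM is a limit of the assay and not a number. Compound 2 also stands at a limit, so neither step to compound 3, from compound 2 or from compound 1, can be read. On these data alone, whether nitro and cyano differ here remains open.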